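The source may hold more compounds than are shown below. What is called first, only, known or untested is meant among the compounds shown, and "the series" means these compounds.

Compound 3 `Cn1c(-c2ccccc2F)nnc1[S+](C)[O-]` gives 20 mg/kg in a functional assay on the whole organism for antagonist activity, with Mus musculus as the target (a lower number here means that less compound is needed, a higher number that more compound is needed for the effect), within the scatter of compound 1 `Cn1c(-c2ccccc2)nnc1[S+](C)[O-]` at 18.6 mg/kg. Compound 2 `CCSc1nnc(-c2ccccc2)n1C` reads > 200 mg/kg, and that is a limit of the assay, not a number.

Compound 4 `CCSc1nnc(-c2ccccc2F)n1C` carries ethylsulfanyl on an aromatic carbon between two ring nitrogen atoms, where compound 3 has a group with no common name: a group of 3 heavy atoms (2 carbon, 1 sulfur; no ring) in place of a group of 3 heavy atoms (1 carbon, 1 oxygen, 1 sulfur; no ring), on an aromatic carbon.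

Among the compounds with values here, two measured steps bear on this change. The same exchange without the fluoro gave a large step, an at least 10-fold higher number from compound 1 to compound 2 (1.03 log units; beyond the scatter). Fluoro in place of hydrogen gave none beyond the scatter, a 1.1-fold higher number from compound 1 to compound 3 (0.03 log units; within the scatter). Within the data shown here, the large step is therefore expected to carry over to the fluoro compounds, though only one pair supports this. A large step towards a higher number is expected in this assay, estimated as a 15-fold higher number from compound 3 to compound 4 (1.18 log units; beyond the scatter). Compound 4 may also report only as a limit, given (the limit of > 200 mg/kg in this assay, at which 1 of the 3 values shown sits). For compound 4 the expected value is 300 mg/kg, with an estimated range from 100 mg/kg to 800 mg/kg.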

Compound 4, dose for half-maximal effect: 18.6 mg/kg
Estimate against measurement, compound 4: 16-fold (1.21 log units) above; the measured number lies below the stated range.
By their numbers in this assay, from the lowest: compounds 1, 4 and 3 (each within the scatter of the next). At a limit, above all of these: compound 2.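

Ethylsulfanyl on this aromatic carbon between two ring nitrogen atoms is tolerated once the fluoro is present, with a 1.1-fold lower number from compound 3 to compound 4 (0.03 log units; within the scatter) in this assay. The exchange therefore does not read the same on the two cores: the same change on two cores in this assay, an at least 10-fold higher number (1.03 log units; beyond the scatter) from compound 1 to compound 2 and a 1.1-fold lower number (0.03 log units; within the scatter) from compound 3 to compound 4, at least 11-fold (1.06 log units) apart, beyond the scatter of two such steps

Fluoro in place of hydrogen also reads differently depending on the group at this position, with an at least 10-fold lower number from compound 2 to compound 4 (1.03 log units; beyond the scatter): the same change on two cores in this assay, a 1.1-fold higher number (0.03 log units; within the scatter) from compound 1 to compound 3 and an at least 10-fold lower number (1.03 log units; beyond the scatter) from compound 2 to compound 4, at least 11-fold (1.06 log units) apart, beyond the scatter of two such steps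

Open, on these data alone, is whether this dependence extends to other groups at this position, such as a longer chain like propylsulfanyl, or to chloro in place of the fluoro. The interplay rests on these four compounds alone, so how far it holds beyond them remains unsettled.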